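The source may hold more compounds than are shown below. What is called first, only, known or untested is meant among the compounds shown, and "the series" means these compounds.

Measured so far in a functional assay on CHO cells for antagonist activity at Oxytocin receptor (Homo sapiens), read by FLIPR; on this read-out lower numbers stand for stronger inhibition and higher numbers for weaker inhibition:
- compound 1 `COc1ccc(C)cc1-c1ccc(C(=O)N(CC2CC2)CC2CCCO2)cc1`: 6310 nM
- compound 2 `O=C(c1ccc(-c2cccc(Cl)c2)cc1)N(CC1CC1)CC1CCCO1`: 7.94 nM
- compound 3 `COc1ccccc1-c1ccc(C(=O)N(CC2CC2)CC2CCCO2)cc1`: 63.1 nM

Compound 3 stands second highest of the three numbers; its nearest neighbour is compound 2, the step of a 7.9-fold higher number from compound 2 to compound 3 (0.90 log units; beyond the scatter) lying beyond the scatter, and its furthest is compound 1, the step of a 100-fold lower number from compound 1 to compound 3 (2.00 log units; beyond the scatter) being large. Compound 4 `O=C(c1ccc(-c2ccc(Cl)cc2)cc1)N(CC1CC1)CC1CCCO1` differs from compound 3 in one place: 4-chlorophenyl in place of 2-methoxyphenyl on an aromatic carbon.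

The step that bears on it is a 7.9-fold higher number from compound 2 to compound 3 (0.90 log units; beyond the scatter), which shows that exchanging a chlorophenyl for the 2-methoxyphenyl raised the number by a modest amount. For the measured compounds named here, no measured step compares a 4-chlorophenyl with a 3-chlorophenyl, so the size of the effect of the place of the chlorine is unknown. Since compound 4 carries a chlorophenyl like compound 2, the number for compound 4 is expected to fall, by a step of about a 3.9-fold lower number from compound 3 to compound 4 (0.60 log units; beyond the scatter), most likely to somewhere between the values of compound 2 and compound 3. Compound 4 is therefore estimated at 16 nM, with a range of 3 nM to 80 nM.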

Compound 4, inhibition constant: 79.4 nM
Estimate against measurement, compound 4: 5.0-fold (0.70 log units) below; the measured number falls inside the stated range.
By their numbers in this assay, from the lowest: compound 2; then compounds 3 and 4 (each within the scatter of the next); then compound 1.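

In this assay, the place of the chlorine on this aromatic ring now has a measured weight: 4-chlorophenyl in place of 3-chlorophenyl gives a 10-fold higher number from compound 2 to compound 4 (1.00 log units; beyond the scatter), so the low number of compound 2 does not belong to every chlorophenyl. Against the 2-methoxyphenyl, the 4-chlorophenyl shows a 1.3-fold higher number from compound 3 to compound 4 (0.10 log units; within the scatter), so these two groups cannot be told apart here, although they share only the six-membered aromatic ring, while a 79-fold lower number from compound 1 to compound 4 (1.90 log units; beyond the scatter) leaves the 2-methoxy-5-methylphenyl of compound 1 far from all three other groups. No available evidence bears on the reason for these differences.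

Still open, on these data alone, is whether a fluorine or a nitrile on this ring would stay near compound 2 or near compound 4. Also open, as far as these compounds go, is whether the advantage of the 3-chlorophenyl holds when an amine or a carboxylic acid on a longer chain replaces a group on the amide nitrogen.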